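The source may report more compounds than this note shows. Statements on the series, on what has been measured and on what is new or still open speak of the compounds shown alone.

Within the data shown here, in a toxicity assay on Huh-7.5 cells (Homo sapiens) for inhibition, read by MTT assay, with a stated time of 96 h (a higher number here means that more compound is tolerated, a lower number that less compound is tolerated), compound 1 (`CN1CCN(Cc2ccc(NC(=O)c3ccc(OCCCCl)c(F)c3)cc2C(F)(F)F)CC1`) gives 8800 nM as the lower of the two numbers so far. Compound 2 (`CCOc1ccc(C(=O)Nc2ccc(OC)cc2)cc1NC(=O)CC`) stands at 73200 nM and is not linked to compound 1 by a change in one place. Compound 3 (`CN1CCN(Cc2ccc(NC(=O)c3ccc(OCCCCl)c([N+](=O)[O-])c3)cc2C(F)(F)F)CC1`) is compound 1 with nitro in place of fluoro on an aromatic carbon, ortho to a 3-chloropropoxy group (nitro in place of fluoro on an aromatic carbon). Among the measured compounds shown here, no measured step covers this change, so no shift beyond the scatter is expected in this assay, and no direction is favoured. Compound 3 is expected at 10000 nM with an estimated range of 4000 nM to 25000 nM for now.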

Compound 3, half-maximal cytotoxic concentration: 6800 nM
Estimate against measurement, compound 3: 1.5-fold (0.17 log units) above; the range from low to high includes it.
By their numbers in this assay, from the lowest: compounds 3 and 1 (each within the scatter of the next); then compound 2.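

In this assay, among these compounds, nitro in place of fluoro on this aromatic carbon, ortho to a 3-chloropropoxy group, gives a 1.3-fold lower number from compound 1 to compound 3 (0.11 log units; within the scatter) and provides the first one-place step. At this position, the three heavy atoms of nitro and the single fluorine cannot be told apart in this read-out. No separate data on either group accompany this result. From the compounds shown here alone, whether an amine or a nitrile on this carbon would read the same remains open. So does whether a longer chain in place of the 3-chloropropoxy group would shift the number.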